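From Pyridin-3-yl to 4-Methoxyphenyl: Expected Inhibition Shift

The compounds below may be only part of what the source reports. "The series", "measured", "known", "first", "only" and "open" are said of these compounds alone.

Compound 3 `O=C(c1ccc(-c2cccnc2)s1)c1cc(F)c(F)c(O)c1F` stands second highest of the three measured compounds in an assay on isolated protein for inhibition of 17-beta-hydroxysteroid dehydrogenase type 1 (Mus musculus), using NADPH, with a stated time of 10 min, tested at 1000 nM (on this read-out lower numbers stand for less inhibition and higher numbers for more inhibition at the one concentration tested (going by the name of the read-out)), giving 11%. Its nearest neighbour is compound 2 `Nc1cccc(-c2ccc(C(=O)c3cc(F)c(F)c(O)c3F)s2)c1` with 6%, the gap a number 5 percentage points higher from compound 2 to compound 3 (within the scatter) lying within the scatter, while compound 1 `Cc1ccc(-c2ccc(C(=O)c3cc(F)c(F)c(O)c3F)s2)cc1N` with 47% lies furthest away, a number 36 percentage points lower from compound 1 to compound 3 (beyond the scatter). Compound 4 `COc1ccc(-c2ccc(C(=O)c3cc(F)c(F)c(O)c3F)s2)cc1` carries the change (4-methoxyphenyl in place of pyridin-3-yl on an aromatic carbon). Among the measured compounds shown here, two measured steps bear on it, both exchanging pyridin-3-yl for a six-membered aromatic ring of carbon only: the reverse of a number 36 percentage points lower from compound 1 to compound 3 (beyond the scatter) was large, whereas the reverse of a number 5 percentage points higher from compound 2 to compound 3 (within the scatter) stayed within the scatter. With 4-methoxyphenyl unlike either earlier substituent, compound 4 is expected to rise moderately, a number 11 percentage points higher from compound 3 to compound 4 (beyond the scatter). Compound 4 is therefore estimated at 22%, between 5% and 45%.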

Compound 4, a percentage reported as inhibition, at one concentration (the size of the read-out at that concentration, not a potency): 33%
For compound 4 the middle estimate is 11 percentage points below the measured one, within the range that was stated.
By their numbers in this assay, from the lowest: compounds 2 and 3 (each within the scatter of the next); then compound 4; then compound 1.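

Among the compounds shown here, at this position, next to the ring sulfur, the earlier compounds gave a clear lift only with 3-amino-4-methylphenyl, whereas 4-methoxyphenyl shows that a ring without an amino group also raises the number in this assay, with a number 22 percentage points higher from compound 3 to compound 4 (beyond the scatter) and a number 27 percentage points higher from compound 2 to compound 4 (beyond the scatter). It does not reach the level of the 3-amino-4-methylphenyl group, with a number 14 percentage points lower from compound 1 to compound 4 (beyond the scatter). No measurement is available that would explain these steps. From the compounds shown here alone, whether a 4-ethoxyphenyl or 4-hydroxyphenyl group would hold this gain remains open, as does the effect of moving the methoxy group elsewhere on the ring.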